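Amine replacements for the aryl ether linker of compound 1

A few compounds are considered here, and "the series" means these few. Any claim that something is new, unique, unknown or untested is made for them only; others in the source may bear on it.

Measured so far:
compound 1 `Cc1ccc(NC(=O)Nc2cc(-c3ccccc3C(=O)O)ccc2Oc2ccccc2C(C)(C)C)cc1` gives 70 nM in an assay on HeLa cells for inhibition of Indoleamine 2,3-dioxygenase 1 (Homo sapiens), with stated times of 1 h and 18 h; on this read-out higher numbers stand for weaker inhibition and lower numbers for stronger inhibition
compound 2 `Cc1ccc(NC(=O)Nc2cc(-c3ccccc3C(=O)O)ccc2N(C)c2ccccc2C(C)(C)C)cc1` gives > 1000 nM in this assay, a limit rather than a number

Compound 2 stands at the weak end of the two values shown: the step of an at least 14-fold higher number from compound 1 to compound 2 (1.15 log units; beyond the scatter) is beyond the scatter, and compound 2 sits at the limit of > 1000 nM in this assay, at which 1 of the 2 values shown sits. Compound 3 `Cc1ccc(NC(=O)Nc2cc(-c3ccccc3C(=O)O)ccc2NC2CCCCC2)cc1` takes the change (cyclohexylamino in place of methyl(2-(tert-butyl)phenyl)amino on an aromatic carbon). Within the data shown here, the only measured step that bears on it is the one from compound 1 to compound 2, where exchanging the ether oxygen for a methylated aryl amine cost a large amount; compound 3 keeps a nitrogen linker but carries a smaller, non-aromatic ring and an amine hydrogen, so the data give no direct precedent. The step of an at least 2.0-fold lower number from compound 2 to compound 3 (0.30 log units; that floor lies within the scatter) is expected to be a partial recovery, with wide uncertainty. Compound 3 is therefore estimated at 500 nM, between 100 nM and 3000 nM.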

Compound 3, half-maximal inhibitory concentration: 504 nM
Beside the measured number, compound 3's estimate is 1.0-fold (0.00 log units) below it; the measured number falls inside the stated range.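

Cyclohexylamino on this aromatic carbon gives a measured number in this assay rather than a limit, yet the result is a 7.2-fold higher number from compound 1 to compound 3 (0.86 log units; beyond the scatter), so this amine linker does not match 2-(tert-butyl)phenoxy. Compound 2 is held only as a limit: the limit of > 1000 nM in this assay, at which 1 of the 3 values shown sits. The comparison with it gives only a floor, an at least 1.9-fold lower number from compound 2 to compound 3 (0.29 log units; that floor lies within the scatter), so no order can be claimed between the two amine linkers.

The change from compound 2 to compound 3 alters the ring and the amine hydrogen together, so their separate contributions remain unresolved. Still open, going by these compounds, is how a cyclohexyloxy group on the same carbon would compare with cyclohexylamino, and whether a 2-(tert-butyl)phenylamino group, lacking the methyl on nitrogen, would sit closer to compound 1 or to compound 2.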